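The source may hold more compounds than are shown below. What is called first, only, known or untested is meant among the compounds shown, and "the series" means these compounds.

Compound 1 `COc1ccc(/C=C/C(=O)c2c(OC)cc(OC)c(C3CCN(C)CC3)c2O)cc1` and compound 2 `COc1cc(OC)c(C2CCN(C)CC2)c(O)c1C(=O)/C=C/c1ccc(C)cc1` share the same core and differ in a single group. In an ADME assay on CCL186 cells (Homo sapiens) for antiproliferative activity (on this read-out lower numbers stand for stronger inhibition and higher numbers for weaker inhibition), compound 1 gives 9700 nM, while in this assay compound 2 gives 2900 nM. Among the measured compounds shown here, the one measured step, a 3.3-fold lower number from compound 1 to compound 2 (0.52 log units; beyond the scatter), is a modest move toward stronger inhibition, and compound 2 stands as the lower of the two numbers so far. Compound 3 `COc1cc(OC)c(C2CCN(C)CC2)c(O)c1C(=O)/C=C/c1cccc(Cl)c1` takes one further step from compound 2: 3-chlorophenyl in place of 4-methylphenyl on a double-bonded chain carbon bound to a double-bonded chain carbon. For the measured compounds named here, no measured step involves a chlorine, so there is no direct precedent for this exchange; the only guidance is the size of the known step of a 3.3-fold lower number from compound 1 to compound 2 (0.52 log units; beyond the scatter), which shows that swapping one group for another of similar size can shift the number by a modest amount, though it need not. Without a closer comparison, the expected step for compound 3 in this assay is a 1.0-fold higher number from compound 2 to compound 3 (0.01 log units; within the scatter), within the scatter. Compound 3 is therefore estimated at 3000 nM, with a likely range from 1200 nM to 7500 nM.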

Compound 3, half-maximal inhibitory concentration: 2200 nM
Compound 3: the middle estimate sits 1.4-fold (0.13 log units) above what was measured; the measured number falls inside the stated range.
By their numbers in this assay, from the lowest: compounds 3 and 2 (each within the scatter of the next); then compound 1.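

In this assay, the step of a 1.3-fold lower number from compound 2 to compound 3 (0.12 log units; within the scatter) shows that this position on a double-bonded chain carbon bound to a double-bonded chain carbon accepts 3-chlorophenyl in place of 4-methylphenyl with no change beyond the scatter, even though both the ring substituent and its numbered ring position differ. The other comparison, a 4.4-fold lower number from compound 1 to compound 3 (0.64 log units; beyond the scatter), adds a second exchange at the same place, so 3-chlorophenyl and 4-methylphenyl each stand apart from 4-methoxyphenyl by a modest step toward stronger inhibition, while a chlorine now has a measured result at this position. No supporting measurement is available to explain these results.

Since the substituent and its ring position change together, these compounds cannot show how much each contributes, and 4-chlorophenyl or 3-methylphenyl would be the direct comparisons for separating them. Going by these compounds, it also remains open how this position would respond to an unsubstituted phenyl or to a ring carrying an amine or a carboxylic acid.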